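Swapping Hydroxy for Phenyl on the Shared Core

The compounds below may be only part of what the source reports. "The series", "measured", "known", "first", "only" and "open" are said of these compounds alone.

Compound 1 `CCOC(=O)C(=O)Nc1ccccc(Oc2ccccc2)c1=O` gives 16% in a functional assay on the whole organism (strain Sprague-Dawley CD) for inhibition, with Rattus norvegicus as the target, read by paw edema, at a dose of 30 mg/kg by the intraperitoneal route; a lower number here means a weaker effect, a higher number a stronger effect of the compound at the dose given.
Compound 2 `CCOC(=O)C(=O)Nc1ccccc(O)c1=O` gives 61% in this assay.
Compound 3 `CCOC(=O)C(=O)Nc1ccccc(N(C)C(=O)C(=O)OCC)c1=O` gives 51% in this assay.

Compound 2 stands highest of the three numbers in this assay. Compound 3 comes nearest, with a number within the usual scatter of that of compound 2, so the two cannot be ordered. Compound 1 lies furthest, beyond the scatter. The step from compound 1 to compound 2 is a number 45 percentage points higher from compound 1 to compound 2 (beyond the scatter) and rests on hydrogen in place of phenyl on an oxygen on an aromatic ring.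

Compound 4 `CCOC(=O)C(=O)Nc1ccccc(-c2ccccc2)c1=O` has not yet been measured. It differs from compound 2 by phenyl in place of hydroxy on an aromatic carbon. Among the compounds with values here, the only measured step that bears on this change is the one from compound 1 to compound 2, where a phenyl left and the number rose by a number 45 percentage points higher from compound 1 to compound 2 (beyond the scatter). Compound 4 carries a phenyl once more, now directly on an aromatic carbon, and gives up the hydroxy that compound 2 bears. Within the data shown here, no measured pair shows this exact exchange, so the size is uncertain, but a step downward in this assay is expected. Compound 4 is estimated at 30%, within a range of 10% to 55%, which means an expected step of a number 31 percentage points lower from compound 2 to compound 4 (beyond the scatter).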

Compound 4, a percentage reported as inhibition, in the whole organism at one dose (the size of the read-out at that dose, not a potency): 72%
Estimate against measurement, compound 4: 42 percentage points below; measured number above the stated range.
By their numbers in this assay, from the lowest: compound 1; then compounds 3 and 2 (each within the scatter of the next); then compound 4.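

Placing phenyl directly on the aromatic carbon of the seven-membered ring gives a number 11 percentage points higher from compound 2 to compound 4 (beyond the scatter) in this assay, so the hydroxy, with its hydrogen-bond donor and acceptor, is not needed for a high number at this position. The phenyl ring alone also does not account for the low number seen with phenoxy, since the exchange of phenoxy for phenyl at the same carbon gives a number 56 percentage points higher from compound 1 to compound 4 (beyond the scatter) and is the largest step yet seen at this position. Among these compounds, the outcome therefore depends on how the aromatic ring is attached, not merely on whether a phenyl ring is present, and the hydroxy and phenyl groups both outperform phenoxy. Nothing here offers an explanation for the difference between directly attached phenyl and oxygen-linked phenyl.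

On these data alone, it remains open whether other groups on this aromatic carbon, such as methoxy, an amine or a carboxylic acid, would keep the number high. As far as these compounds go, it is equally open whether a phenyl ring bearing a chloro or methoxy group, or a benzyl group with a single carbon as its link, would behave like phenyl or like phenoxy.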